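This account rests on a few compounds, and the source may have more. Where it says the series, first, only, none or still open, it means among the compounds named here.

Compound 3 (`N#Cc1ccc(-c2cc(CO[C@@H]3COc4nc([N+](=O)[O-])cn4C3)on2)cc1`) stands at the edge of what the numbers can show. In an ADME assay on Vero cells (Chlorocebus sabaeus) for cytotoxicity, with a stated time of 72 h (a lower number here means a stronger inhibitor, a higher number a weaker inhibitor), compound 3 gives > 128000 nM, which is a limit of the assay and not a number. Compound 1 (`N#Cc1ccc(-c2cccc(CO[C@@H]3COc4nc([N+](=O)[O-])cn4C3)c2)cc1`) in this assay likewise gives > 128000 nM, a limit. Compound 2 (`COc1ccc(-c2ccc(CO[C@@H]3COc4nc([N+](=O)[O-])cn4C3)s2)cn1`) in this assay gives > 128000 nM, again a limit. All three values coincide at the limit of > 128000 nM in this assay, at which 3 of the 3 values shown sit. Compound 4 (`COc1ccc(-c2cc(CO[C@@H]3COc4nc([N+](=O)[O-])cn4C3)on2)cn1`) carries 6-methoxypyridin-3-yl in place of 4-cyanophenyl on an aromatic carbon, that is, 6-methoxypyridin-3-yl in place of 4-cyanophenyl on an aromatic carbon. Among the measured compounds shown here, none of the measured compounds yields a number in this assay. The expected step is a step that the limit leaves unreadable from compound 3 to compound 4, none beyond the scatter. Compound 4 is accordingly expected to give 150000 nM in this assay, within a range from 100000 nM to 300000 nM, most probably reported once more only as a limit.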

Compound 4, half-maximal inhibitory concentration: > 128000 nM
Compound 4: a limit, no number; the forecaster's own chance of this, stated with the estimate: 90%; the middle value does not contradict the limit.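

Among the compounds shown here, no step from compound 3 to compound 4 can be read, because both values are limits and not numbers: the limit of > 128000 nM in this assay, at which 4 of the 4 values shown sit. The compounds shown leave open at what concentration any of them would reach half-maximal inhibition in this assay.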